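Extending the cyanoacetyl arm of compound 1 with two thioethers

The compounds below may be only part of what the source reports. "The series", "measured", "known", "first", "only" and "open" are said of these compounds alone.

Measured compounds:
compound 1 `C/C(=N\NC(=O)CC#N)c1ccc(NS(=O)(=O)c2ccc(Cl)cc2)cc1` — 8000 nM
compound 2 `C/C(=N\NC(=O)C(C#N)C(=S)S)c1ccc(NS(=O)(=O)c2ccc(Cl)cc2)cc1` — 17500 nM

Of the compounds shown here, two sharing the same sulfonamide-bearing core have been measured in a functional assay on HepG2 cells (Homo sapiens) for cytotoxicity, read by sulforhodamine B assay, with a stated time of 48 h; a higher number here means a weaker inhibitor, a lower number a stronger inhibitor. Compound 1 gives 8000 nM, the lower of the two numbers. Compound 2, which carries a group of one carbon and two sulfur atoms on the chain carbon between the carbonyl and the nitrile, gives 17500 nM; the step of a 2.2-fold higher number from compound 1 to compound 2 (0.34 log units; beyond the scatter) is modest but beyond the scatter.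

Compound 3 `CSC(SC)=C(C#N)C(=O)N/N=C(\C)c1ccc(NS(=O)(=O)c2ccc(Cl)cc2)cc1` has not yet been measured in this assay. Relative to compound 1 the change is 1-cyano-2,2-bis(methylsulfanyl)ethenyl in place of cyanomethyl on a carbonyl carbon. Going by the values given here, the one measured step that bears on it is a 2.2-fold higher number from compound 1 to compound 2 (0.34 log units; beyond the scatter), where sulfur was likewise placed on that chain carbon and the number rose somewhat. On that basis a step of similar size and in the same direction, or no step beyond the scatter, is expected for compound 3, as a 1.5-fold higher number from compound 1 to compound 3 (0.18 log units; within the scatter). Compound 3 is therefore estimated at 12000 nM, with a range from 5000 nM to 30000 nM.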

Compound 3, half-maximal inhibitory concentration: 19400 nM
Beside the measured number, compound 3's estimate is 1.6-fold (0.21 log units) below it; measured number inside the range.
By their numbers in this assay, from the lowest: compound 1; then compounds 2 and 3 (each within the scatter of the next).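

In this assay, 1-cyano-2,2-bis(methylsulfanyl)ethenyl in place of cyanomethyl on the carbonyl carbon gives a 2.4-fold higher number from compound 1 to compound 3 (0.38 log units; beyond the scatter) and so is a second change at this position that leaves compound 1 with the lower number, though only by a modest step. Going by these compounds alone, the exchange of one sulfur-bearing group for the other on the same carbonyl carbon gives a 1.1-fold higher number from compound 2 to compound 3 (0.04 log units; within the scatter) and therefore does not separate the two sulfur-bearing groups, so the added atoms and the double bond counted for the group in compound 3 bring no step that can be read in this assay. Nothing available here accounts for either step.

The compounds shown leave open whether sulfur itself matters, which a group carrying two methoxy groups in place of the two methylsulfanyl groups would address. They also leave open whether any group on this carbonyl carbon, such as an amine, a carboxylic acid or a longer chain, could give a number lower than that of compound 1, as both changes seen so far go the other way.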